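Swapping nitro for chloro: what to expect of compound 4

The compounds below may be only part of what the source reports. "The series", "measured", "known", "first", "only" and "open" are said of these compounds alone.

Measured in a functional assay on MDA-MB-231 cells (Homo sapiens) for cytotoxicity, read by MTT assay, with a stated time of 48 h; a lower number here means a stronger inhibitor, a higher number a weaker inhibitor:
compound 1 `CCn1c(/C=C2/C(=O)Nc3ccccc32)nc2ccccc21`: > 50000 nM (a limit of the assay, not a number)
compound 2 `CCn1c(/C=C2/C(=O)Nc3ccc(C)cc32)nc2ccccc21`: 40600 nM
compound 3 `Cn1c(/C=C2/C(=O)Nc3ccc([N+](=O)[O-])cc32)nc2ccccc21`: "not determined" (no result reported)

Compound 3 has no number to start from. On these data alone, its entry reads "not determined" (no result reported), so its standing in this assay is unknown. Compound 4 `Cn1c(/C=C2/C(=O)Nc3ccc(Cl)cc32)nc2ccccc21` differs from it in one place, with chloro in place of nitro on an aromatic carbon. With no starting value, this change cannot be applied to a number, and no direction can be given for it.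

Among the measured compounds shown here, only one measured step offers any guidance, and it involves a different change, methyl in place of hydrogen on an aromatic carbon. The step is an at least 1.2-fold lower number from compound 1 to compound 2 (0.09 log units; that floor lies within the scatter), which lies within the scatter. Compound 1 is a limit case: the limit of > 50000 nM in this assay, at which 1 of the 3 values shown sits. The estimate therefore rests on the general level of the two neighbours, not on a step size. For the measured compounds named here, compound 2 gives the only true number, 40600 nM, and a similarly high reading is the reasonable expectation for the new compound. That reading may also come back only as a limit. Compound 4 is expected at about 35000 nM, with an estimated range of 12000 nM to 60000 nM.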

Compound 4, half-maximal inhibitory concentration: 37600 nM
For compound 4 the middle estimate is 1.1-fold (0.03 log units) below the measured one, within the range that was stated.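

Compound 3 has no reported result in this assay, so no new step can be read between compound 3 and compound 4, and the swap of nitro for chloro cannot be given a size. The compounds shown leave open how that swap changes the reading on the shared core, whether towards a stronger or a weaker inhibitor.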